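Fluoro to methyl on the benzoyl ring of the thiosemicarbazide series

A few compounds are considered here, and "the series" means these few. Any claim that something is new, unique, unknown or untested is made for them only; others in the source may bear on it.

Measured compounds:
compound 1 `COc1cc2ncnc(NNC(=S)NC(=O)c3ccccc3Cl)c2cc1OC` gives 9670 nM in a functional assay on CNE-2 cells (Homo sapiens) for cytotoxicity, read by MTT assay, with a stated time of 72 h; on this read-out higher numbers stand for weaker inhibition and lower numbers for stronger inhibition
compound 2 `COc1cc2ncnc(NNC(=S)NC(=O)c3ccccc3F)c2cc1OC` gives 12700 nM in this assay
compound 3 `COc1cc2ncnc(NNC(=S)NC(=O)c3ccc(F)cc3)c2cc1OC` gives 16100 nM in this assay

Compound 3 carries the highest number of the three, but this says little: the steps of a 1.7-fold higher number from compound 1 to compound 3 (0.22 log units; within the scatter) and a 1.3-fold higher number from compound 2 to compound 3 (0.10 log units; within the scatter) both lie within the scatter, as does a 1.3-fold higher number from compound 1 to compound 2 (0.12 log units; within the scatter). Across the shared core, moving a fluoro or exchanging chloro for fluoro on the benzoyl ring has left the read-out essentially flat.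

Compound 4 `COc1cc2ncnc(NNC(=S)NC(=O)c3ccc(C)cc3)c2cc1OC` differs from compound 3 by methyl in place of fluoro on an aromatic carbon. For the measured compounds named here, no measured step swaps a halogen for methyl, so the relevant evidence is indirect: the three small steps above show that changes of this kind on the benzoyl ring have so far stayed within the scatter. On that basis no step beyond the scatter is expected in this assay from compound 3 to compound 4; the expected step is a 1.0-fold lower number from compound 3 to compound 4 (0.00 log units; within the scatter). For compound 4 the estimated value in this assay is 16000 nM, with an expected range from 8000 nM to 32000 nM.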

Compound 4, half-maximal inhibitory concentration: 33300 nM
The estimate for compound 4 lay 2.1-fold (0.32 log units) below the measured number; measured number above the stated range.
By their numbers in this assay, from the lowest: compounds 1, 2 and 3 (each within the scatter of the next); then compound 4.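

For the compounds shown here, at the ring carbon that carries fluoro in compound 3, methyl gives the first change in this assay to lie beyond the scatter: a 2.1-fold higher number from compound 3 to compound 4 (0.32 log units; beyond the scatter). The comparisons with the two compounds bearing a halogen at a different ring carbon run the same way, with a 2.6-fold higher number from compound 2 to compound 4 (0.42 log units; beyond the scatter) and a 3.4-fold higher number from compound 1 to compound 4 (0.54 log units; beyond the scatter), so the flat read-out among compound 1, compound 2 and compound 3 does not extend to the 4-methylphenyl group. No available data account for this difference between fluoro and methyl.

On these data alone, with methyl as the only non-halogen substituent on this ring, it remains open whether the weaker inhibition is specific to methyl or would also appear with a methoxy, an amine or a longer chain such as propyl at this carbon. Also open, as far as these compounds go, is how methyl behaves at the ring carbon that carries chloro in compound 1.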